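The compounds below may be only part of what the source reports. "The series", "measured", "known", "first", "only" and "open" are said of these compounds alone.

Measured so far in a functional assay on MT4 cells (Homo sapiens) for cytotoxicity; on this read-out higher numbers stand for weaker inhibition and lower numbers for stronger inhibition:
- compound 1 `CCOc1cc(C)cc(S(=O)(=O)c2cccc(N)c2C#N)c1`: 9000 nM
- compound 2 `Cc1cc(C)cc(S(=O)(=O)c2cccc(F)c2C#N)c1`: > 200000 nM (a limit, not a number)
- compound 3 `COc1cc(C)cc(S(=O)(=O)c2cccc(F)c2C#N)c1`: 8000 nM

Compound 2 has no number of its own and stands at the limit of > 200000 nM in this assay, at which 1 of the 3 values shown sits. Compound 4 `Cc1cc(C)cc(S(=O)(=O)c2cccc(NC3CCCCC3)c2C#N)c1` has not yet been measured. It differs from compound 2 by cyclohexylamino in place of fluoro on an aromatic carbon, ortho to a cyano group (cyclohexylamino in place of fluoro on an aromatic carbon).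

Among the measured compounds shown here, no measured step changes the fluoro group itself, so the evidence is indirect. For the measured compounds named here, the one measured step, an at least 25-fold lower number from compound 2 to compound 3 (1.39 log units; beyond the scatter), is a large one, made by methoxy in place of methyl on an aromatic carbon. It shows that a single change to compound 2 can bring the read-out down into a measurable range. Going by the values given here, compound 1, the only measured compound with an amino group, gives 9000 nM, and this lies in that same range. A large step towards a lower number in this assay is therefore expected, although its size stays uncertain and the result could remain at the limit. The expected step is an at least 6.6-fold lower number from compound 2 to compound 4 (0.82 log units; beyond the scatter). For compound 4 the estimated value is 30000 nM, with an expected range from 6000 nM to 200000 nM.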

Compound 4, half-maximal inhibitory concentration: > 200000 nM
Compound 4 ended at the assay's limit; the forecaster's own chance of this, stated with the estimate: 30%; middle value at least 6.6-fold (0.82 log units) away from the limit.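

In this assay compound 4 gives > 200000 nM, which is a limit and not a number. Among the compounds shown here, compound 2 also stands at a limit, so no step between compound 2 and compound 4 can be read: the limit of > 200000 nM in this assay, at which 2 of the 4 values shown sit. The compounds shown leave open whether cyclohexylamino in place of fluoro on an aromatic carbon changes the read-out at all.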